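A Side-Chain Swap at the Assay Limit

The compounds below may be only part of what the source reports. "The series", "measured", "known", "first", "only" and "open" are said of these compounds alone.

In an ADME assay on PBMC cells (Homo sapiens) for cytotoxicity, with a stated time of 5 days (a lower number here means a stronger inhibitor, a higher number a weaker inhibitor), compound 3 (`[N-]=[N+]=N[C@H]1C[C@H](n2cnc3c(NC4CC4)nc(N)nc32)O[C@@H]1CO`) gives > 100000 nM as a limit of the assay, not a number. Compound 1 (`COc1nc(NC2CC2)c2ncn([C@H]3C[C@H](N=[N+]=[N-])[C@@H](CO)O3)c2n1`) gives > 100000 nM as a limit too. Compound 2 (`[N-]=[N+]=N[C@H]1C[C@H](n2cnc3c(NCCCCCO)nc(N)nc32)O[C@@H]1CO`) likewise gives > 100000 nM as a limit. Everything measured so far therefore rests on the limit of > 100000 nM in this assay, at which 3 of the 3 values shown sit, alone.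

Compound 4 (`C=CCN(C)c1nc(N)nc2c1ncn2[C@H]1C[C@H](N=[N+]=[N-])[C@@H](CO)O1`) differs from compound 3 by allyl(methyl)amino in place of cyclopropylamino on an aromatic carbon. Going by the values given here, two measured steps bear on this change, and neither has a size that can be read: a step that the two limits leave unreadable from compound 2 to compound 3 for a change on the nitrogen, and a step that the two limits leave unreadable from compound 1 to compound 3 for a different group. They offer no sign of a move in either direction, so no shift beyond the usual scatter is expected. The estimated outcome is a number no higher from compound 3 to compound 4 (the limit leaves the size open) and no more. For compound 4 the expected value is 100000 nM within an estimated range from 30000 nM to 300000 nM and the assay will quite likely report only a limit again.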

Compound 4, half-maximal inhibitory concentration: > 100000 nM
Compound 4: no number, only a limit; the forecaster's own chance of this, stated with the estimate: 85%; the middle value sits exactly at the limit.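

In this assay compound 4 gives > 100000 nM, a limit and not a number, so its steps from compound 3 and from compound 2 cannot be read. The compounds shown leave open whether any of these side chains on the shared core changes the result at all: the limit of > 100000 nM in this assay, at which 4 of the 4 values shown sit.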